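A few compounds are considered here, and "the series" means these few. Any claim that something is new, unique, unknown or untested is made for them only; others in the source may bear on it.

Measured compounds in an ADME assay on microsomes from liver (Rattus norvegicus) for metabolic stability, read by LC-MS, tested at 0.5 uM; a lower number here means that the compound disappears faster, a higher number that the compound lasts longer:

compound 1 `COc1cccc(CCOc2ccc(-c3c(C)nc(C)c([C@H](OC(C)(C)C)C(=O)O)c3N3CCC(C)(C)CC3)cc2)c1`: > 2 h
compound 2 `Cc1nc(C)c([C@H](OC(C)(C)C)C(=O)O)c(N2CCC(C)(C)CC2)c1-c1ccc(OCCc2ccc(F)c(F)c2)cc1`: 0.85 h
compound 3 `Cc1nc(C)c([C@H](OC(C)(C)C)C(=O)O)c(N2CCC(C)(C)CC2)c1-c1ccc(OCCCc2ccc(F)cc2)cc1`: > 2 h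

Compound 3 stands at a limit of this assay; its half-life is not a number but a limit (> 2 h). Compound 1 likewise sits at a limit (> 2 h). Among the compounds with values here, compound 2 is the only one with a read number, and in this assay compound 2 gives 0.85 h. The readable steps are an at least 2.3-fold lower number from compound 1 to compound 2 (0.37 log units; beyond the scatter) and an at least 2.3-fold higher number from compound 2 to compound 3 (0.37 log units; beyond the scatter); the step that the two limits leave unreadable from compound 1 to compound 3 cannot be sized because of the limit of > 2 h in this assay, at which 2 of the 3 values shown sit.

Compound 4 `Cc1nc(C)c([C@H](OC(C)(C)C)C(=O)O)c(N2CCC(C)(C)CC2)c1-c1ccc(OC2COCC2c2ccc(F)cc2)cc1` differs from compound 3 by 4-(4-fluorophenyl)oxolan-3-yl in place of 3-(4-fluorophenyl)propyl on an oxygen on an aromatic ring. Within the data shown here, none of the measured steps touches this part of the molecule: all three swap the aryl group at the end of the chain, while here the chain itself is replaced by an oxolane ring. The measured steps therefore give no direct guide, and with compound 3 at a limit the starting point is itself unreadable. In this assay compound 4 is expected to remain near the limit or somewhat below it, with a wide range. The estimated step from compound 3 is an at least 1.2-fold lower number from compound 3 to compound 4 (0.09 log units; that floor lies within the scatter). The estimate for compound 4 is 1.6 h, between 0.7 h and 3.5 h.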

Compound 4, half-life: > 2 h
Compound 4 ended at the assay's limit; the forecaster's own chance of this, stated with the estimate: 40%; middle value at least 1.2-fold (0.09 log units) from the limit.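

Replacing the open chain on an oxygen on an aromatic ring with 4-(4-fluorophenyl)oxolan-3-yl changes the chain itself, not only the aryl group at its end, and in this assay compound 4 still sits at a limit, > 2 h. Against the only read number in the set, this substituent gives an at least 2.3-fold higher number from compound 2 to compound 4 (0.37 log units; beyond the scatter). The steps from compound 1 and compound 3 to compound 4 cannot be read, because all three compounds share one bound: the limit of > 2 h in this assay, at which 3 of the 4 values shown sit.

On these data alone, how far compound 4 lies past its limit stays open, and with it whether the oxolane ring gains or loses anything against 3-(4-fluorophenyl)propyl. Also open, as far as these compounds go, is whether a 3,4-difluorophenyl group on the oxolane ring, or a pyrrolidine amine in place of the oxolane, would stay at this limit in this assay.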